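Methoxy in place of fluoro: notes on the series

The compounds below may be only part of what the source reports. "The series", "measured", "known", "first", "only" and "open" are said of these compounds alone.

In a functional assay on NCI-H460 cells (Homo sapiens) for inhibition, read by CCK-8 assay, with a stated time of 72 h (on this read-out higher numbers stand for weaker inhibition and lower numbers for stronger inhibition), compound 1 (`Nc1ccccc1NC(=O)c1ccc(CNC(=O)c2n[nH]cc2NC(=O)c2c(Cl)cccc2Cl)cc1`) gives 4190 nM and compound 2 (`Nc1ccccc1NC(=O)c1ccc(CNC(=O)c2n[nH]cc2NC(=O)c2ccccc2F)cc1`) gives 9990 nM, the higher of the two numbers. Compound 3 (`COc1ccccc1C(=O)Nc1c[nH]nc1C(=O)NCc1ccc(C(=O)Nc2ccccc2N)cc1`) keeps the rest of compound 2 and carries methoxy in place of fluoro on an aromatic carbon, ortho to a large group (methoxy in place of fluoro on an aromatic carbon). Going by the values given here, only one measured step bears on this change: a 2.4-fold higher number from compound 1 to compound 2 (0.38 log units; beyond the scatter), a modest one, in which 2-fluorophenyl replaced 2,6-dichlorophenyl on a carbonyl carbon. Among the compounds with values here, no measured compound carries methoxy, so the data do not fix a direction. In this assay a step of no greater size than that one is expected, most likely none beyond the scatter. The estimated step is a 1.3-fold lower number from compound 2 to compound 3 (0.12 log units; within the scatter). For compound 3 the expected value is 7500 nM, with an estimated range of 3200 nM to 17000 nM.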

Compound 3, half-maximal inhibitory concentration: 7350 nM
Compound 3: the middle estimate sits 1.0-fold (0.01 log units) above what was measured, and the stated range covers the measured number.
By their numbers in this assay, from the lowest: compounds 1, 3 and 2 (each within the scatter of the next, the first and the last beyond it).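

In this assay methoxy in place of fluoro on an aromatic carbon, ortho to a large group, gives a 1.4-fold lower number from compound 2 to compound 3 (0.13 log units; within the scatter) and so the extra heavy atom and the hydrogen-bond acceptor that enter here bring no step beyond the scatter. Setting 2-methoxyphenyl in place of 2,6-dichlorophenyl gives a 1.8-fold higher number from compound 1 to compound 3 (0.24 log units; within the scatter) and so compound 3 cannot be separated from either compound 1 or compound 2, although those two stand apart by a 2.4-fold higher number from compound 1 to compound 2 (0.38 log units; beyond the scatter) and remain the only pair in the series that does. Nothing measured on these compounds offers an explanation for the size of these steps.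

Open, from the compounds shown here alone, is whether an amine, a carboxylic acid or a longer chain such as ethoxy in this place would give a step beyond the scatter from compound 2. Also open, going by these compounds, is whether a 2,6-dimethoxyphenyl group would behave like the 2,6-dichlorophenyl of compound 1 or like the 2-methoxyphenyl of compound 3.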